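This account rests on a few compounds, and the source may have more. Where it says the series, first, only, none or still open, it means among the compounds named here.

Measured compounds:
compound 1 `Nc1cccc2c(-c3cccc(NC(=O)c4cccc(C(F)(F)F)c4)c3)ccnc12` — 7900 nM
compound 2 `Nc1cccc2c(-c3cccc(NC(=O)c4ccc(Cl)c(C(F)(F)F)c4)c3)ccnc12` — 1400 nM
compound 3 `Nc1cccc2c(-c3cccc(NC(=O)c4cc(Cl)cc(C(F)(F)F)c4)c3)ccnc12` — 18500 nM

In a functional assay on A375P cells (Homo sapiens) for antiproliferative activity, read by MTT assay, with a stated time of 48 h (a higher number here means a weaker inhibitor, a lower number a stronger inhibitor), compound 1 stands second highest of the three numbers. Compound 2 lies a 5.6-fold lower number from compound 1 to compound 2 (0.75 log units; beyond the scatter) away, and compound 3 lies a 2.3-fold higher number from compound 1 to compound 3 (0.37 log units; beyond the scatter) away. Both of those steps place a chloro on the ring that carries the trifluoromethyl group. Compound 4 `CC(=O)Nc1cccc2c(-c3cccc(NC(=O)c4cccc(C(F)(F)F)c4)c3)ccnc12` differs from compound 1 at another place: acetyl in place of hydrogen on a nitrogen on an aromatic ring. Among the measured compounds shown here, no measured step touches that nitrogen, so the two chloro steps do not bear on this change and give it no direction. A step within the scatter is therefore expected, namely a 1.1-fold higher number from compound 1 to compound 4 (0.06 log units; within the scatter). Compound 4 is estimated at 9000 nM, with a range from 3500 nM to 25000 nM.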

Compound 4, half-maximal inhibitory concentration: 8000 nM
Compound 4: the middle estimate sits 1.1-fold (0.05 log units) above what was measured; the measured number falls inside the stated range.
By their numbers in this assay, from the lowest: compound 2; then compounds 1 and 4 (each within the scatter of the next); then compound 3.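

In this assay, turning amino into acetamido gives a 1.0-fold higher number from compound 1 to compound 4 (0.01 log units; within the scatter) and so, unlike the two chloro steps on the ring carrying the trifluoromethyl group, this change stays within the scatter. For this pair, the hydrogen on this nitrogen can be replaced by acetyl with no shift that can be told from the scatter. No evidence at hand accounts for this result. Open, from the compounds shown here alone, is whether a methyl group, a longer acyl chain or a sulfonyl group on this nitrogen would do the same, and whether acetyl would leave the number as unmoved with the chloro of compound 2 or compound 3 present.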